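The source may report more compounds than this note shows. Statements on the series, on what has been measured and on what is new or still open speak of the compounds shown alone.

Measured so far in a toxicity assay on WI-38 cells (Homo sapiens) for cytotoxicity, read by MTT assay, with a stated time of 48 h; a higher number here means a weaker inhibitor, a lower number a stronger inhibitor: compound 1 `O=C(/C=C/c1ccc2c(c1)B(O)OC2)c1cccs1` gives 26000 nM. Compound 2 `O=C(/C=C/c1ccc2c(c1)B(O)OC2)c1ccc(I)cc1` gives only a limit, > 100000 nM.

Compound 2 thus stands at a limit of this assay, (the limit of > 100000 nM in this assay, at which 1 of the 2 values shown sits), with no number of its own. Compound 3 `O=C(/C=C/c1ccc2c(c1)B(O)OC2)c1ccc(O)cc1` differs from it by hydroxy in place of iodo on an aromatic carbon. Among the measured compounds shown here, the one measured step, an at least 3.8-fold higher number from compound 1 to compound 2 (0.58 log units; beyond the scatter), replaces the whole aryl group on the carbonyl carbon and does not touch the hydroxy-for-iodo change, so no measured step bears on it directly. With compound 2 at a limit, compound 3 is expected to remain near that limit, an estimated a number no higher from compound 2 to compound 3 (the limit leaves the size open). The estimate for compound 3 is 100000 nM, within 30000 nM to 300000 nM.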

Compound 3, half-maximal inhibitory concentration: > 100000 nM
Compound 3 was reported as a limit; the forecaster's own chance of this, stated with the estimate: 55%; the middle value sits exactly at the limit.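

In this assay compound 3, like the iodo compound, gives only a limit, > 100000 nM. The 4-hydroxyphenyl group also gives an at least 3.8-fold higher number from compound 1 to compound 3 (0.58 log units; beyond the scatter), so this shift away from thiophen-2-yl does not depend on iodo. The step from iodo to hydroxy cannot be read, and the two groups now share one ceiling: the limit of > 100000 nM in this assay, at which 2 of the 3 values shown sit.

Any order between iodo and hydroxy at this position stays open. From the compounds shown here alone, whether an amine or a carboxylic acid on the same aromatic carbon would return a readable number in this assay also stays open.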